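Two-ring N-oxide series: acyl azide to isopropyl carbamate

The compounds below may be only part of what the source reports. "The series", "measured", "known", "first", "only" and "open" are said of these compounds alone.

Measured so far:
compound 1 `CCOc1ccc(NCc2nc3cc(OC)ccc3[n+]([O-])c2-c2ccccc2)cc1`: 97.6%
compound 2 `COc1ccc2c(c1)[n+]([O-])c(C(=O)N=[N+]=[N-])c(C)[n+]2[O-]`: 80.7%

For the measured compounds named here, in a functional assay on Ehrlich cells (Mus musculus) for cytotoxicity, read by trypan blue exclusion, with a stated time of 2 h, tested at 25 ug/mL (a higher number here means a weaker effect of the compound at the concentration tested, a lower number a stronger effect), compound 2 gives 80.7%, the lower of the two numbers known; compound 1 gives 97.6%, a gap beyond the scatter. Compound 3 `COc1ccc2c(c1)[n+]([O-])c(NC(=O)OC(C)C)c(C)[n+]2[O-]` is not yet measured. It differs from compound 2 in one place: a group of 7 heavy atoms (4 carbon, 1 nitrogen, 2 oxygen; no ring) in place of a group of 5 heavy atoms (1 carbon, 3 nitrogen, 1 oxygen; no ring), on an aromatic carbon. Going by the values given here, no measured pair shows this change, so no step for it is known. The step from compound 2 to compound 3 is estimated at a number 7.3 percentage points higher from compound 2 to compound 3 (within the scatter), a modest rise in the number that may stay within the scatter. Compound 3 is therefore expected to give 88%, within 72% to 99%.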

Compound 3, a percentage reported as activity, at one concentration (the size of the read-out at that concentration, not a potency): 97%
Beside the measured number, compound 3's estimate is 9 percentage points below it; measured number inside the range.
By their numbers in this assay, from the lowest: compound 2; then compounds 3 and 1 (each within the scatter of the next).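

In this assay, (isopropoxycarbonyl)amino in place of the acyl azide, on the aromatic carbon next to the ring nitrogen, gives a number 16.3 percentage points higher from compound 2 to compound 3 (beyond the scatter). For the compounds shown here, this is the first sign that the group at this position matters: the stronger effect at the tested concentration goes with the acyl azide of compound 2, not with the carbamate. Nothing available explains this step.

As far as these compounds go, whether a free amine or a carboxylic acid at this carbon would stand nearer compound 2 or compound 3 remains open. So does whether the step would hold on another core.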